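The source may hold more compounds than are shown below. What is called first, only, known or untested is meant among the compounds shown, and "the series" means these compounds.

Within the data shown here, in an ADME assay on the whole organism (Mus musculus, strain C57BL/6J) for pharmacokinetics, with a stated time of 24 h, at a dose of 2 mg/kg by the intravenous route (a higher number here means faster removal of the compound, a lower number slower removal), compound 2 `CCCCOc1nc(-c2ccc(F)cc2)c(-c2ccc(S(C)(=O)=O)cc2)cc1CO` gives 32.2 mL/min/kg and is the lower of the two numbers so far. Compound 3 `CCCCOc1nc(OCC2(C)COC2)c(-c2ccc(S(C)(=O)=O)cc2)cc1CO` differs from it at one place: (3-methyloxetan-3-yl)methoxy in place of 4-fluorophenyl on an aromatic carbon with (3-methyloxetan-3-yl)methoxy in place of 4-fluorophenyl on an aromatic carbon. Among the measured compounds shown here, no measured pair shows this change directly. Compound 1 `CCCOc1nc(OCC(C)(C)O)c(-c2ccc(S(C)(=O)=O)cc2)cc1CO` also lacks the 4-fluorophenyl group and gives 92.7 mL/min/kg as the higher number, so a rise just beyond the scatter is expected. That is an estimated step of a 2.2-fold higher number from compound 2 to compound 3 (0.34 log units; beyond the scatter) toward faster removal. For compound 3 the estimated clearance is 70 mL/min/kg with a likely range from 32 mL/min/kg to 150 mL/min/kg at the upper end.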

Compound 3, clearance: 89.3 mL/min/kg
Compound 3: the middle estimate sits 1.3-fold (0.11 log units) below what was measured; the range from low to high includes it.
By their numbers in this assay, from the lowest: compound 2; then compounds 3 and 1 (each within the scatter of the next).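

Placing (3-methyloxetan-3-yl)methoxy instead of 4-fluorophenyl on the aromatic carbon next to the ring nitrogen gives a 2.8-fold higher number from compound 2 to compound 3 (0.44 log units; beyond the scatter) in this assay, the first direct sign that this position bears on how fast the compound is removed. Of this pair, the compound with 4-fluorophenyl has the slower removal. No measurement at hand explains the step. Still open, going by these compounds, is whether the fluorine or the aromatic ring goes with the slower removal. A plain phenyl or a simple amine on the same carbon would help to separate these possibilities.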